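Turning One Ring Stereocentre: From Compound 2 to Compound 3

A few compounds are considered here, and "the series" means these few. Any claim that something is new, unique, unknown or untested is made for them only; others in the source may bear on it.

Compound 1 `CC(=O)N[C@H]1[C@@H](OC2=CC(=O)c3ccccc3C2=O)O[C@H](COC(C)=O)[C@@H](OC(C)=O)[C@@H]1OC(C)=O` and compound 2 `CC(=O)O[C@H]1[C@H](OC(C)=O)[C@H](OC2=CC(=O)c3ccccc3C2=O)O[C@@H](C)[C@H]1OC(C)=O` have both been tested in a functional assay on MDA-MB-231 cells (Homo sapiens) for cytotoxicity, read by sulforhodamine B assay, with a stated time of 72 h; a lower number here means a stronger inhibitor, a higher number a weaker inhibitor. Compound 1 gives 19800 nM, and compound 2 gives 18200 nM; these two numbers lie within the scatter of each other, so neither stands apart. Compound 3 `CC(=O)O[C@H]1[C@H](OC(C)=O)[C@@H](OC2=CC(=O)c3ccccc3C2=O)O[C@@H](C)[C@H]1OC(C)=O` has not yet been measured. It differs from compound 2 in one respect: the two compounds have the same atoms and bonds and differ only in configuration as drawn: 1 of 5 stereo elements differ; a stereocentre at a saturated ring carbon is drawn S in compound 2 and R in compound 3. Among the compounds with values here, no measured pair here shows what such a change does, so the expectation rests on compound 2 alone. In this assay the step is expected to stay small, with no clear direction, namely a 1.2-fold higher number from compound 2 to compound 3 (0.08 log units; within the scatter). Compound 3 is estimated at 22000 nM, within 8000 nM to 60000 nM.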

Compound 3, half-maximal inhibitory concentration: 8650 nM
Compound 3: middle estimate off by 2.5-fold (0.41 log units), on the high side; the measured number falls inside the stated range.
By their numbers in this assay, from the lowest: compound 3; then compounds 2 and 1 (each within the scatter of the next).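

In this assay, within the data shown here, turning this one saturated ring carbon from S to R gives a 2.1-fold lower number from compound 2 to compound 3 (0.32 log units; beyond the scatter) and so moves the number beyond the scatter, a modest step, but one that no earlier pair could show. Configuration at this position alone is therefore enough to shift the result, because no atom or bond changes: the fact that compounds 2 and 3 differ only in the configuration as drawn. Still open, on these data alone, is whether free hydroxyl groups or an amine in place of the acetate esters would keep this gap between the two configurations.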